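Dimethylamino Tail on the Ester Chain of Compound 2

The source may report more compounds than this note shows. Statements on the series, on what has been measured and on what is new or still open speak of the compounds shown alone.

Measured compounds:
compound 1, `Nc1ccc(-c2cc(=O)c3c(N)c(F)c(CO)c(F)c3o2)cc1F`: 24000 nM
compound 2, `CCCCCC(=O)OCc1c(F)c(N)c2c(=O)cc(-c3ccc(N)c(F)c3)oc2c1F`: 34000 nM

In a functional assay on HeLa cells (Homo sapiens) for cytotoxicity, read by neutral red uptake, with a stated time of 3 days (on this read-out lower numbers stand for stronger inhibition and higher numbers for weaker inhibition), compound 1 gives 24000 nM. In this assay compound 2 gives 34000 nM. Within the data shown here, the only step among the measured compounds is a 1.4-fold higher number from compound 1 to compound 2 (0.15 log units; within the scatter). Compound 2 thus has one neighbour, compound 1, and the two numbers lie within the scatter of each other, so neither can be placed above the other.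

Compound 3, `CN(C)CCCC(=O)OCc1c(F)c(N)c2c(=O)cc(-c3ccc(N)c(F)c3)oc2c1F`, has not been measured. Its difference from compound 2 is dimethylamino in place of ethyl on a saturated chain carbon, three bonds along the chain from a carbonyl carbon. Among the measured compounds shown here, no measured step touches this part of the chain; the one step known, from a hydrogen to a pentylcarbonyl on the same oxygen, stayed within the scatter. From this compound 3 is expected to show a step of no change at the digits printed from compound 2 to compound 3 (within the scatter), that is, nothing beyond the scatter. Compound 3 is therefore estimated at 34000 nM, within a range from 12000 nM to 100000 nM.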

Compound 3, half-maximal inhibitory concentration: 4500 nM
Estimate against measurement, compound 3: 7.6-fold (0.88 log units) above; the whole stated range lies above it.
By their numbers in this assay, from the lowest: compound 3; then compounds 1 and 2 (each within the scatter of the next).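

In this assay, among these compounds, the far end of the ester chain proves to matter: dimethylamino in place of ethyl gives a 7.6-fold lower number from compound 2 to compound 3 (0.88 log units; beyond the scatter) on an otherwise unchanged compound, a step beyond the scatter, whereas the one earlier step at this part of the molecule stayed within it. The ester on this oxygen is therefore not inert as a whole, since (3-(dimethylamino)propyl)carbonyl in place of hydrogen gives a 5.3-fold lower number from compound 1 to compound 3 (0.73 log units; beyond the scatter) while pentylcarbonyl in that place did not move the number beyond the scatter. Nothing available accounts for this step.

On these data alone, it remains open whether another amine at the chain end, such as a primary amine or morpholine, would give a similar step, or whether a carboxylic acid there would not. As far as these compounds go, how a longer or shorter chain between the carbonyl and the dimethylamino would read also remains open.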